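The compounds below may be only part of what the source reports. "The series", "measured", "known", "first", "only" and "open" are said of these compounds alone.

In an ADME assay on MT4 cells (Homo sapiens) for cytotoxicity (a higher number here means that more compound is tolerated, a lower number that less compound is tolerated), compound 2 `COc1ccc(C(=O)CSc2nc(Cc3cccc(Br)c3)c(C)c(=O)[nH]2)cc1` gives >= 196000 nM, which is a limit of the assay rather than a measured number. Compound 1 `COc1ccc(C(=O)CSc2nc(Cc3ccccc3Br)c(C)c(=O)[nH]2)cc1` gives > 272000 nM, likewise only a limit. The step that the two limits leave unreadable from compound 1 to compound 2 therefore cannot be read from those two limits. Compound 3 `COc1ccc(C(=O)CSc2nc(Cc3cccc(O)c3)c(C)c(=O)[nH]2)cc1` differs from compound 2 by hydroxy in place of bromo on an aromatic carbon. Among the compounds with values here, no measured step bears on this change, so nothing in the data points to a shift in this assay in either direction. Compound 3 is expected to show a step that the limit leaves unreadable from compound 2 to compound 3. The estimate for compound 3 is 200000 nM, within a range from 50000 nM to 400000 nM, and most likely again reported only as a limit.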

Compound 3, half-maximal cytotoxic concentration: 70000 nM
Estimate against measurement, compound 3: 2.9-fold (0.46 log units) above; the measured number falls inside the stated range.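

In this assay, within the data shown here, compound 3 is the first compound here with a measured number rather than a limit, and changing the group at this place on the aromatic ring does register: hydroxy in place of bromo gives an at least 2.8-fold lower number from compound 2 to compound 3 (0.44 log units; beyond the scatter), and the 1>3 change gives an at least 3.8-fold lower number from compound 1 to compound 3 (0.58 log units; beyond the scatter). Compound 2 stands only at a limit, so the true step from it may be larger: the limit of >= 196000 nM in this assay, at which 1 of the 3 values shown sits. The step between the two bromo compounds cannot be read.

As far as these compounds go, it remains open whether hydroxy is special here, or whether an amine or a carboxylic acid at this place would lower the number as well.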